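Swapping Piperidin-1-yl for Thiophen-2-ylmethyl in a Benzamide

A few compounds are considered here, and "the series" means these few. Any claim that something is new, unique, unknown or untested is made for them only; others in the source may bear on it.

Compound 1 `BrCCCc1ccc(-c2ccc(-c3cccs3)s2)s1`: 35300 nM
Compound 2 `O=C(NCCN1CCCCC1)c1cc(F)cc(C(F)(F)F)c1`: 1370000 nM
Compound 3 `O=C(NCCCCc1ccc(-c2ccc(-c3cccs3)s2)s1)c1cc(F)cc(C(F)(F)F)c1`: "not determined" (no result reported)

In an ADME assay on MDCK cells (Canis lupus familiaris) for cytotoxicity, read by MTT assay, with a stated time of 2 days (on this read-out lower numbers stand for higher toxicity in this test and higher numbers for lower toxicity in this test), compound 1 gives 35300 nM, while compound 2 gives 1370000 nM. In this assay compound 3 gives "not determined" (no result reported). Compound 2 stands highest of the two numbers; the nearest is compound 1, and that gap lies beyond the usual scatter. Compound 4 `O=C(NCCCc1cccs1)c1cc(F)cc(C(F)(F)F)c1` differs from compound 2 by (thiophen-2-yl)methyl in place of piperidin-1-yl on a saturated chain carbon, two bonds along the chain from an amide-type nitrogen. Among the measured compounds shown here, no step between measured compounds matches this change. Because compound 1, which also bears a thiophen-2-yl group, gives 35300 nM, a downward step from compound 2 to compound 4 of a 2.7-fold lower number from compound 2 to compound 4 (0.44 log units; beyond the scatter) is expected, modestly beyond the scatter. Compound 4 is therefore estimated at 500000 nM, with a range from 120000 nM to 1400000 nM.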

Compound 4, half-maximal cytotoxic concentration: 40200 nM
For compound 4 the middle estimate is 12-fold (1.09 log units) above the measured one, outside the stated range (below it).
By their numbers in this assay, from the lowest: compounds 1 and 4 (each within the scatter of the next); then compound 2.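

In this assay the change to (thiophen-2-yl)methyl in place of piperidin-1-yl, on a saturated chain carbon, two bonds along the chain from an amide-type nitrogen, gives a 34-fold lower number from compound 2 to compound 4 (1.53 log units; beyond the scatter) and so shows that the read-out responds strongly to the group at this position. The two groups match in heavy atoms, donors and acceptors, so those counts do not separate them. Nothing measured here accounts for the step. From the compounds shown here alone, what a dimethylamine or a benzyl group would give at this position remains open, so the step cannot yet be assigned to the loss of the nitrogen or to the aromatic ring.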